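Capping the piperidine nitrogen with an acetyl group

The source may report more compounds than this note shows. Statements on the series, on what has been measured and on what is new or still open speak of the compounds shown alone.

Compound 1 `O=C(N[C@H]1CN(S(=O)(=O)c2ccccc2)C[C@@H]1C(=O)N[C@H]1CCCNC1)c1cc(-c2ccccc2Cl)on1` and compound 2 `O=C(N[C@H]1CN(S(=O)(=O)c2ccccc2)C[C@@H]1C(=O)N[C@H]1CCCNC1)c1cc(-c2ccc(Cl)cc2Cl)on1` share one core and differ only in a chloro in place of hydrogen on an aromatic carbon. In a functional assay on HEK293 cells for agonist activity at growth hormone secretagogue receptor type 1 (Homo sapiens), read by HTRF and inositol phosphate accumulation, with a stated time of 90 min, in the presence of a further agent that is not named here (a lower number here means a smaller maximal response, a higher number a larger maximal response), compound 1 gives 98%, while compound 2 gives 109%; this is a number 11 percentage points higher from compound 1 to compound 2 (beyond the scatter). Among the compounds with values here, compound 1 therefore stands lowest of the two numbers measured so far, with compound 2 as its only neighbour.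

Compound 3 `CC(=O)N1CCC[C@H](NC(=O)[C@H]2CN(S(=O)(=O)c3ccccc3)C[C@@H]2NC(=O)c2cc(-c3ccccc3Cl)on2)C1` is not yet measured. It differs from compound 1 in one place: acetyl in place of hydrogen on an amine nitrogen in a ring. Within the data shown here, no measured step touches this position; the only step recorded concerns an aromatic carbon elsewhere in the core, so nothing here shows what an acetyl on the ring amine does. Both measured compounds reach close to a full response, so compound 3 is expected to stay near that level, with an expected step of a number 3 percentage points lower from compound 1 to compound 3 (within the scatter). For compound 3 the estimate is 95%, in a range from 78% to 112%.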

Compound 3, largest response reached (Emax), in percent of the reference or control that the assay uses: 91%
Compound 3: the middle estimate sits 4 percentage points above what was measured; low and high end bracket the measured number.
By their numbers in this assay, from the lowest: compounds 3 and 1 (each within the scatter of the next); then compound 2.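

Placing an acetyl on the amine nitrogen of the piperidin-3-yl group gives, in this assay, a number 7 percentage points lower from compound 1 to compound 3 (within the scatter). Within the data shown here, this is the first measured step at this ring nitrogen, and it shows that, in this series, the hydrogen there can give way to an acetyl while the maximal response stays within the scatter of that of compound 1. No measurement available here explains how the response holds up once the 1-acetylpiperidin-3-yl group is present.

Still open, from the compounds shown here alone, is whether a longer acyl chain, a methyl group or a methanesulfonyl group on the same nitrogen would be tolerated as well as the acetyl. Also open, going by these compounds, is whether the second chloro of compound 2 would bring the same step on top of the acetyl.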